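A few compounds are considered here, and "the series" means these few. Any claim that something is new, unique, unknown or untested is made for them only; others in the source may bear on it.

For the measured compounds named here, compound 3 `Cc1ccc(NC(=O)c2ccc(C)c(C(F)(F)F)c2)cc1C#Cc1nn(C[C@@H](C)CO)c2ncnc(N)c12` gives 123 nM in a functional assay on MDA-MB-435 cells (Homo sapiens) for antiproliferative activity, read by MTT assay, with a stated time of 72 h (a lower number here means a stronger inhibitor, a higher number a weaker inhibitor), the highest of the three numbers measured so far. Compound 1 `Cc1ccc(NC(=O)c2cccc(C(F)(F)F)c2)cc1C#Cc1nn(C[C@@H](C)CO)c2ncnc(N)c12` gives 10 nM, and compound 2 `Cc1ccc(NC(=O)c2cnc(C(C)(C)C)s2)cc1C#Cc1nn(C[C@@H](C)CO)c2ncnc(N)c12` gives 73 nM. The step of a 12-fold higher number from compound 1 to compound 3 (1.09 log units; beyond the scatter) is large, whereas a 1.7-fold higher number from compound 2 to compound 3 (0.23 log units; within the scatter) stays within the scatter and a 7.3-fold higher number from compound 1 to compound 2 (0.86 log units; beyond the scatter) is modest.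

Compound 4 `Cc1ccc(NC(=O)c2ccc(Cl)c(C(F)(F)F)c2)cc1C#Cc1nn(C[C@@H](C)CO)c2ncnc(N)c12` differs from compound 3 by chloro in place of methyl on an aromatic carbon. Going by the values given here, the only measured step touching this carbon is a 12-fold higher number from compound 1 to compound 3 (1.09 log units; beyond the scatter), in which a methyl entered for hydrogen and the number rose clearly. Among the compounds with values here, no chloro analogue has been measured, so whether chloro at that carbon behaves like the methyl of compound 3 or like the hydrogen of compound 1 cannot be read from these three compounds. Compound 4 is therefore expected to lie between those two, and its expected step reads a 2.1-fold lower number from compound 3 to compound 4 (0.31 log units; beyond the scatter). Compound 4 is estimated at 60 nM, with a range from 15 nM to 250 nM.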

Compound 4, half-maximal inhibitory concentration: 319 nM
Compound 4: the middle estimate sits 5.3-fold (0.73 log units) below what was measured; the whole stated range lies below it.
By their numbers in this assay, from the lowest: compound 1; then compounds 2 and 3 (each within the scatter of the next); then compound 4.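

In this assay, chloro at this carbon does not move the number back towards the hydrogen of compound 1: exchanging methyl for chloro goes further in the same direction (  a 2.6-fold higher number from compound 3 to compound 4 (0.41 log units; beyond the scatter)  ), and the full change from hydrogen to chloro is (  a 32-fold higher number from compound 1 to compound 4 (1.50 log units; beyond the scatter)  ). Compound 3 could not be separated from the thiazole amide compound 2, but the 4-chloro-3-(trifluoromethyl)phenyl amide can (  a 4.4-fold higher number from compound 2 to compound 4 (0.64 log units; beyond the scatter)  ). Nothing available explains why either group on this carbon ortho to the trifluoromethyl group raises the number over hydrogen.

Only hydrogen, methyl and chloro are shown at this carbon, so it remains open whether a fluoro, a methoxy or an amine there would stay near compound 1. Going by these compounds, it is also open whether the order of these groups would hold with a different chain on the shared core.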